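A few compounds are considered here, and "the series" means these few. Any claim that something is new, unique, unknown or untested is made for them only; others in the source may bear on it.

In a functional assay on NB-4 cells (Homo sapiens) for inhibition, read by XTT assay, with a stated time of 48 h (on this read-out lower numbers stand for stronger inhibition and higher numbers for weaker inhibition), compound 2 `COc1ccc(C(=O)/C(=C/c2ccc(Cl)cc2Cl)CCOC(C)=O)cc1` gives 34800 nM, the lowest of the two actual numbers measured here. Compound 3 `CCC(/C=C(\CCOC(C)=O)C(=O)c1ccc(OC)cc1)CC` gives 91100 nM, and the gap between them is a 2.6-fold higher number from compound 2 to compound 3 (0.42 log units; beyond the scatter). Compound 1 `COc1ccc(C(=O)/C(=C/c2ccccc2F)CCOC(C)=O)cc1` gives only > 100000 nM, which is a limit of the assay and not a number. That is the limit of > 100000 nM in this assay, at which 1 of the 3 values shown sits. Starting from that limit, the change to compound 2 reads an at least 2.8-fold lower number from compound 1 to compound 2 (0.45 log units; beyond the scatter), whereas the change to compound 3 reads an at least 1.0-fold lower number from compound 1 to compound 3 (0.04 log units; that floor lies within the scatter).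

Compound 4 `COc1ccc(C(=O)/C(=C/c2ccc(Cl)cc2Cl)CC2CCCCC2)cc1` differs from compound 2 by cyclohexyl in place of acetoxymethyl on a saturated chain carbon bound to a double-bonded chain carbon. Among the compounds with values here, all three measured steps swap the group on the double-bonded chain carbon, and none of them alters the saturated chain carbon where compound 4 differs, so no measured step bears directly on this change. Those steps were modest at most, and nothing in the measured set points to a large movement in either direction for a change at this other position. Staying close to compound 2, compound 4 is therefore expected to give an estimated 30000 nM, within a range from 8000 nM to 120000 nM. This estimate corresponds to an expected step of a 1.2-fold lower number from compound 2 to compound 4 (0.06 log units; within the scatter), which is expected to stay within the scatter.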

Compound 4, half-maximal inhibitory concentration: 48900 nM
Compound 4: middle estimate off by 1.6-fold (0.21 log units), on the low side, within the range that was stated.
By their numbers in this assay, from the lowest: compounds 2, 4 and 3 (each within the scatter of the next, the first and the last beyond it). At a limit, above all of these: compound 1.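

This is the first change shown at the saturated chain carbon bound to a double-bonded chain carbon; the earlier steps all swapped the group on the double-bonded chain carbon. In this assay, putting cyclohexyl in place of acetoxymethyl reads a 1.4-fold higher number from compound 2 to compound 4 (0.15 log units; within the scatter) and so cannot be told apart from repeat-measurement noise, even though a non-ring group with two hydrogen-bond acceptors gives way to a carbon-only six-membered ring with none. With the 2,4-dichlorophenyl group held in place, this read-out therefore does not separate the two groups, and nothing measured here offers an explanation for that.

Going by these compounds, compound 2 and compound 4 both carry 2,4-dichlorophenyl, so it remains open whether the same swap would read alike with 2-fluorophenyl or pentan-3-yl on the double-bonded chain carbon. Within the data shown here, it also remains open whether a primary amine, a carboxylic acid or a longer carbon chain at the saturated chain carbon would move the number beyond the scatter, since acetoxymethyl and cyclohexyl are the only two groups compared at this place.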